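The source may report more compounds than this note shows. Statements on the series, on what has been measured and on what is new or still open speak of the compounds shown alone.

Two compounds from this series have been examined in a physicochemical assay for solubility, read by HPLC; a higher number here means a more soluble compound, a lower number a less soluble compound. Compound 1, `CC[C@@H](C)[C@@H]1C(=O)N[C@H](C2Cc3ccccc3C2)C(=O)N1[C@@H](C(=O)N1CCOCC1)c1ccc(C)nc1`, gives > 280 ug/mL in this assay, and that reading is a limit of the measurement rather than a number. Compound 2, `COc1ccc([C@H](C(=O)N(C)C)N2C(=O)[C@@H](C3Cc4ccccc4C3)NC(=O)[C@H]2CC(C)C)cn1`, gives 216 ug/mL in this assay. Going by the values given here, compound 2 therefore holds the only numerical reading in the set; the other value sits at the limit described by the limit of > 280 ug/mL in this assay, at which 1 of the 2 values shown sits, so the data do not rank the two compounds against each other. Compound 3, `CC(C)C[C@@H]1C(=O)N[C@H](C2Cc3ccccc3C2)C(=O)N1[C@@H](C(=O)N(C)C)c1ccc(N(C)C)nc1`, has not yet been measured. It differs from compound 2 in one place: dimethylamino in place of methoxy on an aromatic carbon. Among the compounds with values here, no pair of measured compounds differs in only one place, so no measured step stands behind this change, and the expectation rests on the structures alone. The step expected in this assay is a small upward one, a 1.2-fold higher number from compound 2 to compound 3 (0.06 log units; within the scatter), which stays within the usual scatter of repeated measurements. The estimate for compound 3 in this assay is accordingly 250 ug/mL, with the likely range running from 120 ug/mL to 450 ug/mL.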

Compound 3, solubility: 233 ug/mL
Compound 3: middle estimate off by 1.1-fold (0.03 log units), on the high side; measured number inside the range.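

Dimethylamino in place of methoxy, on an aromatic carbon next to the ring nitrogen and para to a large group, gives a 1.1-fold higher number from compound 2 to compound 3 (0.03 log units; within the scatter) in this assay. Going by these compounds alone, this is the one measured step at this position, and it gives the change from 6-methoxypyridin-3-yl to 6-(dimethylamino)pyridin-3-yl a measured basis that compound 1 and compound 2 could not supply, since those two differ in more than one place. Here, a group of 3 heavy atoms replaces one of 2, with 1 hydrogen-bond acceptor in each and no net charge, and the readings of the two compounds cannot be told apart.

Still open, on these data alone, is whether a carboxylic acid, a primary amine or a longer alkoxy chain at this position would produce a step beyond the scatter, and whether dimethylamino in place of methoxy would give a similar step with other groups elsewhere on the shared core. Compound 1 remains a limit and not a number, and it contributes no step to this question: the limit of > 280 ug/mL in this assay, at which 1 of the 3 values shown sits.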